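The source may report more compounds than this note shows. Statements on the series, on what has been measured and on what is new or still open speak of the compounds shown alone.

Three compounds have so far been measured in an ADME assay on Vero cells (Chlorocebus sabaeus) for cytotoxicity, read by fluorescence and resazurin assay, with a stated time of 3 days; a higher number here means that more compound is tolerated, a lower number that less compound is tolerated:

Compound 1, `CCOC(=O)C[C@@H]([C@H]1O[C@@H]2OC(C)(C)O[C@@H]2[C@H]1OCc1ccccc1)n1cnc2c(NCc3ccccc3)ncnc21`, gives 57500 nM.
Compound 2, `CC1(C)O[C@H]2O[C@H]([C@H](CCO)n3cnc4c(NCc5ccccc5)ncnc43)[C@H](OCc3ccccc3)[C@H]2O1`, gives 61200 nM.
Compound 3, `CC1(C)O[C@H]2O[C@H]([C@H](CCO)n3cnc4c(N)ncnc43)[C@H](Oc3ccccc3[N+](=O)[O-])[C@H]2O1`, gives 148000 nM.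

Compound 3 stands highest of the three, so that more of it is tolerated by the cells than of compound 2 or compound 1, and both of those gaps lie beyond the usual scatter. Compound 1 and compound 2 sit within the scatter of each other, so no order between them can be read from these numbers.

The unmeasured compound is compound 4, `CCOC(=O)C[C@@H]([C@H]1O[C@@H]2OC(C)(C)O[C@@H]2[C@H]1Oc1ccccc1[N+](=O)[O-])n1cnc2c(N)ncnc21`. It differs from compound 3 in one place: ethoxycarbonyl in place of hydroxymethyl on a saturated chain carbon, two bonds along the chain from an aromatic nitrogen and a saturated ring carbon. The same kind of change has already been made once among the measured compounds, from compound 2 to compound 1, where it reads ethoxycarbonyl in place of hydroxymethyl on a saturated chain carbon, two bonds along the chain from an aromatic nitrogen and a saturated ring carbon and gave a 1.1-fold lower number from compound 2 to compound 1 (0.03 log units; within the scatter). The cores on which the two changes sit are not the same, and the difference between the core of compound 3 and the core of compound 2 is not broken down here.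

Since that earlier change left the result essentially where it was, a similar outcome is expected for compound 4, that is an estimated step of a 1.1-fold lower number from compound 3 to compound 4 (0.02 log units; within the scatter), resting on the step of a 1.1-fold lower number from compound 2 to compound 1 (0.03 log units; within the scatter). Compound 4 is therefore estimated to give about 140000 nM in this assay, with a likely range from 70000 nM to 280000 nM.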

Compound 4, half-maximal cytotoxic concentration: 96300 nM
Beside the measured number, compound 4's estimate is 1.5-fold (0.16 log units) above it, and the stated range covers the measured number.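

In this assay, putting ethoxycarbonyl in place of hydroxymethyl on the core of compound 3 gives a 1.5-fold lower number from compound 3 to compound 4 (0.19 log units; within the scatter) and so moves the result no further than repeated measurements usually scatter. Set side by side, the two examples of this change agree with each other: the same change on two cores in this assay, a 1.1-fold lower number (0.03 log units; within the scatter) from compound 2 to compound 1 and a 1.5-fold lower number (0.19 log units; within the scatter) from compound 3 to compound 4, 1.4-fold (0.16 log units) apart, within the scatter of two such steps.

For the compounds shown here, this shows that, on these two cores, the swap from the small hydroxymethyl group to the larger ethoxycarbonyl group leaves the tolerated concentration unchanged within the scatter, so the earlier step was a fair guide to the later one; it does not show that the change would behave the same way on any other core, and with only two pairs, neither step beyond the scatter, it gives no real direction for the change and no reason for its small size.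

On these data alone, what a carboxylic acid, an amide or a longer chain would do on that saturated chain carbon remains open. As far as these compounds go, compound 2 and compound 3 differ in more than one place, so the separate contribution of each difference between their cores also remains open.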